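This account rests on a few compounds, and the source may have more. Where it says the series, first, only, none or still open, it means among the compounds named here.

Measured compounds:
compound 1 `COc1ncc(-c2ccc3nc(NC(=O)NCCN4CCCC4)sc3c2)cc1NS(=O)(=O)c1ccc(F)cc1` gives 360 nM in a functional assay on U-87MG ATCC cells for antiproliferative activity against U-87 MG (Homo sapiens), read by MTT assay, with a stated time of 72 h; a higher number here means a weaker inhibitor, a lower number a stronger inhibitor
compound 2 `COc1ncc(-c2ccc3nc(NC(=O)NCCN(C)C)sc3c2)cc1NS(=O)(=O)c1ccc(F)cc1` gives 1020 nM in this assay

Among the compounds with values here, compound 2 stands with the highest number of the two; its nearest neighbour is compound 1, and the single step on record, a 2.8-fold higher number from compound 1 to compound 2 (0.45 log units; beyond the scatter), is a modest change lying beyond the scatter. The unmeasured compound 3 `CCN(CC)CCNC(=O)Nc1nc2ccc(-c3cnc(OC)c(NS(=O)(=O)c4ccc(F)cc4)c3)cc2s1` differs from compound 2 by diethylamino in place of dimethylamino on a saturated chain carbon, two bonds along the chain from an amide-type nitrogen. Within the data shown here, the one measured step bears only loosely on this change: it replaced the pyrrolidin-1-yl of compound 1 with dimethylamino, whereas compound 3 keeps an open-chain amine and merely lengthens its two carbon arms. Since diethylamino is neither the pyrrolidin-1-yl of compound 1 nor the dimethylamino of compound 2, compound 3 is expected to fall between them in this assay, with a step of a 1.6-fold lower number from compound 2 to compound 3 (0.20 log units; within the scatter) that may not clear the scatter. The estimate for compound 3 in this assay is 650 nM, ranging from 280 nM to 1500 nM.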

Compound 3, half-maximal inhibitory concentration: 390 nM
Compound 3: middle estimate off by 1.7-fold (0.22 log units), on the high side, within the range that was stated.
By their numbers in this assay, from the lowest: compounds 1 and 3 (each within the scatter of the next); then compound 2.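

In this assay, diethylamino in place of dimethylamino on a saturated chain carbon, two bonds along the chain from an amide-type nitrogen, gives a 2.6-fold lower number from compound 2 to compound 3 (0.42 log units; beyond the scatter), so an open-chain amine at this place does not by itself go with the higher number of compound 2. Diethylamino and pyrrolidin-1-yl cannot be told apart here, with a 1.1-fold higher number from compound 1 to compound 3 (0.03 log units; within the scatter), which shows that among these three compounds only dimethylamino stands apart and that a ring at this place is not needed to reach the level of compound 1.

From the compounds shown here alone, whether piperidin-1-yl, morpholin-4-yl or a longer chain carrying the diethylamino would hold or shift the number remains open. No measurement at hand accounts for these differences.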